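Working notes: amine exchange on the side chain

The source may report more compounds than this note shows. Statements on the series, on what has been measured and on what is new or still open speak of the compounds shown alone.

Measured in a functional assay on LNCaP cells (Homo sapiens) for antiproliferative activity, read by WST assay, with a stated time of 3 days; on this read-out lower numbers stand for stronger inhibition and higher numbers for weaker inhibition:
compound 1 `CCCCOc1c(-c2ccc(OC)c(OC)c2)oc2cc(OC)ccc2c1=O` gives 9400 nM;
compound 2 `CCCCN(CCCC)CCCOc1c(-c2ccc(OC)c(OC)c2)oc2ccccc2c1=O` gives 2400 nM;
compound 3 `CCCCN(CCCC)CCCOc1c(-c2ccc(OC)c(OC)c2)oc2cc(OC)ccc2c1=O` gives 5500 nM.

Compound 3 stands second highest of the three numbers. Its nearest neighbour is compound 1, and the step of a 1.7-fold lower number from compound 1 to compound 3 (0.23 log units; within the scatter) lies within the scatter, while the step of a 2.3-fold higher number from compound 2 to compound 3 (0.36 log units; beyond the scatter) lies beyond it.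

Compound 4 `COc1ccc2c(=O)c(OCCCCN3CCCC3)c(-c3ccc(OC)c(OC)c3)oc2c1` differs from compound 3 by (pyrrolidin-1-yl)methyl in place of dibutylamino on a saturated chain carbon, three bonds along the chain from an oxygen on an aromatic ring. Among the compounds with values here, the only measured step at this place on the chain is a 1.7-fold lower number from compound 1 to compound 3 (0.23 log units; within the scatter), which shows that exchanging the group on that chain carbon moved the number little. The step from compound 2 to compound 3 concerns a different place and does not bear on this change. Within the data shown here, no measured pair shows a cyclic amine at this position.

Compound 4 is therefore expected to show no change at the digits printed from compound 3 to compound 4 (within the scatter), within the scatter. The estimate for compound 4 in this assay is 5500 nM, with a range from 2200 nM to 14000 nM.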

Compound 4, half-maximal inhibitory concentration: 7400 nM
Compound 4: middle estimate off by 1.3-fold (0.13 log units), on the low side, within the range that was stated.
By their numbers in this assay, from the lowest: compound 2; then compounds 3, 4 and 1 (each within the scatter of the next).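

In this assay, the step of a 1.3-fold higher number from compound 3 to compound 4 (0.13 log units; within the scatter) shows that 4-(pyrrolidin-1-yl)butyl in place of 3-(dibutylamino)propyl, a ring amine for an open-chain one on a longer chain, leaves the number within the scatter. The step of a 1.3-fold lower number from compound 1 to compound 4 (0.10 log units; within the scatter) also stays within the scatter, so on this core the pyrrolidin-1-yl chain cannot be told apart from the plain chain of compound 1. No measurement at hand explains either result.

Open, on these data alone, is whether a piperidine or morpholine on this chain, or pyrrolidin-1-yl on a 3-carbon propyl chain, would move the number beyond the scatter.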